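Heteroaryl swap at the core of compound 1

The compounds below may be only part of what the source reports. "The series", "measured", "known", "first", "only" and "open" are said of these compounds alone.

Compound 1 `COc1cc(CSc2cc(Cl)c(-c3nnc(-c4ccc(Cl)cc4)s3)cc2S(=O)(=O)NC(=N)NO)cc(OC)c1OC` gives 25700 nM in a functional assay on SNB-75 cells (Homo sapiens) (on this read-out higher numbers stand for weaker inhibition of growth and lower numbers for stronger inhibition of growth), the highest of the two numbers in hand; compound 2 `N=C(NO)NS(=O)(=O)c1cc(-c2nnc(-c3ccc(Cl)cc3)s2)c(Cl)cc1SCc1ccccc1` gives 1490 nM. Within the data shown here, the one measured step, a 17-fold lower number from compound 1 to compound 2 (1.24 log units; beyond the scatter), concerns the group on the saturated chain carbon bound to sulfur, not the ring pair that changes here, so no step bears on the change to compound 3 `COc1cc(CSc2cc(Cl)c(-c3nc(-c4ccccc4)no3)cc2S(=O)(=O)NC(=N)NO)cc(OC)c1OC`, (3-phenyl-1,2,4-oxadiazol-5-yl in place of 5-(4-chlorophenyl)-1,3,4-thiadiazol-2-yl on an aromatic carbon). With nothing to anchor the direction, the expectation is a modest move, a 1.3-fold lower number from compound 1 to compound 3 (0.11 log units; within the scatter), within a wide band. Compound 3 is therefore estimated at 20000 nM, between 5000 nM and 80000 nM.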

Compound 3, concentration for 50% growth inhibition: 3980 nM
Compound 3: middle estimate off by 5.0-fold (0.70 log units), on the high side; the measured number lies below the stated range.
By their numbers in this assay, from the lowest: compound 2; then compound 3; then compound 1.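

The aromatic carbon ortho to a chloro group proves a second place where the number responds: in this assay, the heteroaryl swap gives a 6.5-fold lower number from compound 1 to compound 3 (0.81 log units; beyond the scatter). This change replaces the five-membered ring and removes the chlorine from the outer phenyl together, so the step cannot be divided between them. Nothing in hand accounts for the step.

Open, on these data alone, is how 3-(4-chlorophenyl)-1,2,4-oxadiazol-5-yl would read at this carbon, which would separate those two changes. Also open, as far as these compounds go, is whether the step holds with phenyl in place of 3,4,5-trimethoxyphenyl on the saturated chain carbon bound to sulfur.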